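A nitro group takes the place of methoxy

The source may hold more compounds than are shown below. What is called first, only, known or untested is meant among the compounds shown, and "the series" means these compounds.

The study covers four compounds on a shared core. Compound 1 `CCOC(=O)C1=Cc2ccccc2OC1(OCc1cn(-c2ccc(F)cc2)nn1)C(F)(F)F` gives 8900 nM in a functional assay on DU-145 cells (Homo sapiens) for inhibition, read by MTT assay, with a stated time of 24 h; a higher number here means a weaker inhibitor, a lower number a stronger inhibitor. Compound 3 `CCOC(=O)C1=Cc2ccccc2OC1(OCc1cn(-c2ccccc2)nn1)C(F)(F)F` reaches only a limit of this assay, > 150000 nM, and not a number. Going by the values given here, the change an at least 16-fold higher number from compound 1 to compound 3 (1.22 log units; beyond the scatter) is the one measured step. Compound 2 `CCOC(=O)C1=Cc2ccccc2OC1(OCc1cc(-c2ccc(OC)cc2)no1)C(F)(F)F` likewise sits at a limit of this assay, > 150000 nM, so its position among the numbers is known only as the limit of > 150000 nM in this assay, at which 2 of the 3 values shown sit. Compound 4 `CCOC(=O)C1=Cc2ccccc2OC1(OCc1cc(-c2ccc([N+](=O)[O-])cc2)no1)C(F)(F)F` is not yet measured; it differs from compound 2 by nitro in place of methoxy on an aromatic carbon. Among the compounds with values here, no measured step concerns this change itself, and the step from compound 1 to compound 3 involves a different ring and a different group, so it shows only that a single change on that ring can be large. With compound 2 at a limit, the expected step of an at least 1.2-fold lower number from compound 2 to compound 4 (0.09 log units; that floor lies within the scatter) is uncertain and may again end at a limit. Compound 4 is estimated at 120000 nM, within 30000 nM to 300000 nM.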

Compound 4, half-maximal inhibitory concentration: > 150000 nM
Compound 4: only a limit was reported; the forecaster's own chance of this, stated with the estimate: 55%; middle value at least 1.2-fold (0.09 log units) away from the limit.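

Compound 2 and compound 4 both sit at a limit and not at a number, so no step between them can be read: the limit of > 150000 nM in this assay, at which 3 of the 4 values shown sit.

The compounds shown leave open whether nitro in place of methoxy changes inhibition at all on the shared core.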